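Swapping a chlorine-bearing ring for a methoxy-bearing one

The source may report more compounds than this note shows. Statements on the series, on what has been measured and on what is new or still open speak of the compounds shown alone.

Compound 3 `Clc1cccc(-c2cn(Cc3ccccc3)c3c2CNCC3)c1` carries a 3-chlorophenyl group on the shared core. In an assay on HEK293 cells for displacement of a labelled ligand from 5-hydroxytryptamine receptor 7 (Rattus norvegicus), with a stated time of 60 min (a higher number here means a weaker inhibitor, a lower number a stronger inhibitor), compound 3 gives 10000 nM, level with compound 2 `CC(C)(C)c1ccc(-c2cn(Cc3ccccc3)c3c2CNCC3)cc1`, which gives 10000 nM, and together these are the highest numbers among the three measured compounds. Compound 1 `Cc1ccc(-c2cn(Cc3ccccc3)c3c2CNCC3)cc1` gives 35 nM, and the step of a 290-fold higher number from compound 1 to compound 3 (2.46 log units; beyond the scatter) shows how far compound 3 sits from it.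

Compound 4 `COc1ccc(-c2cn(Cc3ccccc3)c3c2CNCC3)cc1` differs from compound 3 in one place: 4-methoxyphenyl in place of 3-chlorophenyl on an aromatic carbon. Among the measured compounds shown here, two measured steps bear on this. The change a 290-fold higher number from compound 1 to compound 3 (2.46 log units; beyond the scatter) ran from 4-methylphenyl to 3-chlorophenyl, so moving back to a group on the 4-methylphenyl pattern, here 4-methoxyphenyl, could recover much of that loss. The step of a 290-fold higher number from compound 1 to compound 2 (2.46 log units; beyond the scatter) warns, however, that tert-butyl in place of methyl was costly, so not every group on that pattern behaves like methyl. The expected step is therefore a 67-fold lower number from compound 3 to compound 4 (1.82 log units; beyond the scatter), towards a stronger inhibitor, though probably short of compound 1. Compound 4 is estimated at 150 nM, with an expected range from 25 nM to 1500 nM.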

Compound 4, inhibition constant: 290 nM
Estimate against measurement, compound 4: 1.9-fold (0.29 log units) below; low and high end bracket the measured number.
By their numbers in this assay, from the lowest: compound 1; then compound 4; then compounds 2 and 3 (each within the scatter of the next).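

In this assay, there is a 34-fold lower number from compound 3 to compound 4 (1.54 log units; beyond the scatter) and likewise a 34-fold lower number from compound 2 to compound 4 (1.54 log units; beyond the scatter), so a 4-methoxyphenyl group keeps far more of the inhibition than either the 3-chlorophenyl group or the 4-tert-butylphenyl group. Methoxy still does not fully replace methyl, with an 8.3-fold higher number from compound 1 to compound 4 (0.92 log units; beyond the scatter) in this assay, so this aromatic carbon of the shared core tolerates more than one small group on the ring's 4-position, but these two are not interchangeable. Nothing measured here explains these differences.

Compound 3 changes both the substituent and its place on the ring relative to compound 1 and compound 4, so the compounds shown do not separate the effect of chlorine from that of its position; a 4-chlorophenyl group would address this. From the compounds shown here alone, how an ethoxy group, a longer chain or an amine at the ring's 4-position would compare also remains open.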